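Halogen swap at the benzyloxy terminus of the series

The source may report more compounds than this note shows. Statements on the series, on what has been measured and on what is new or still open speak of the compounds shown alone.

Three compounds of this series carry the same core and differ only in the aryl group on the benzyloxy carbon. In a functional assay on MCF7 cells (Homo sapiens) for antiproliferative activity, read by sulforhodamine B assay, with a stated time of 72 h (a lower number here means a stronger inhibitor, a higher number a weaker inhibitor), compound 1 `Cc1cccc(COc2ccc(-c3cc(CN4CCN(Cc5ccc(C(F)(F)F)cc5)CC4)no3)cc2)c1` gives 4000 nM, compound 2 `FC(F)(F)c1ccc(CN2CCN(Cc3cc(-c4ccc(OCc5ccc(Cl)cc5)cc4)on3)CC2)cc1` gives 6700 nM, and compound 3 `N#Cc1cccc(COc2ccc(-c3cc(CN4CCN(Cc5ccc(C(F)(F)F)cc5)CC4)no3)cc2)c1` gives 800 nM. Compound 2 thus shows the highest number of the three; its nearest neighbour is compound 1, a step of a 1.7-fold higher number from compound 1 to compound 2 (0.22 log units; within the scatter), and its furthest is compound 3, a step of an 8.4-fold lower number from compound 2 to compound 3 (0.92 log units; beyond the scatter). The step of a 5.0-fold lower number from compound 1 to compound 3 (0.70 log units; beyond the scatter) sets the size of the cyano effect.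

Compound 4 `Fc1ccc(COc2ccc(-c3cc(CN4CCN(Cc5ccc(C(F)(F)F)cc5)CC4)no3)cc2)cc1` differs from compound 2 by fluoro in place of chloro on an aromatic carbon. For the measured compounds named here, no measured step swaps one halogen for another; the only step touching this position that stays within scatter is the one from compound 1 to compound 2, while the cyano steps are modest. For compound 4 a step of a 1.3-fold lower number from compound 2 to compound 4 (0.13 log units; within the scatter) in this assay is therefore expected, within scatter. The estimate for compound 4 in this assay is 5000 nM, expected between 2000 nM and 12000 nM.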

Compound 4, half-maximal inhibitory concentration: 7900 nM
For compound 4 the middle estimate is 1.6-fold (0.20 log units) below the measured one; measured number inside the range.
By their numbers in this assay, from the lowest: compound 3; then compounds 1, 2 and 4 (each within the scatter of the next).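

Fluoro in place of chloro gives the first direct halogen comparison at this position, and in this assay the step (a 1.2-fold higher number from compound 2 to compound 4 (0.07 log units; within the scatter)) does not separate the two halogens. The 4-fluorobenzyl compound also cannot be told apart from the 3-methylbenzyl compound (a 2.0-fold higher number from compound 1 to compound 4 (0.30 log units; within the scatter)), whereas the nitrile remains clearly apart (a 9.9-fold higher number from compound 3 to compound 4 (0.99 log units; beyond the scatter)), making compound 3 the only one of the four separated from all the others. Nothing available here accounts for either result.

Open, from the compounds shown here alone, is whether a bromo or methoxy group in place of the fluoro would stay level with the halogens or move toward compound 3. Also open, going by these compounds, is whether 3-chlorophenyl would track 3-cyanophenyl or 3-methylphenyl, which would separate the effect of the nitrile from that of its place on the ring.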